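The source may hold more compounds than are shown below. What is called first, only, known or untested is meant among the compounds shown, and "the series" means these compounds.

Measured in a physicochemical assay for acid dissociation, read by spectrophotometry:
Compound 1 `CCOc1cc(CN2CCC(NC(=O)c3ccc(N)nc3)CC2)cc(OCc2ccccc2)c1-c1ccc(F)cc1`: 7.66
Compound 2 `CCOc1cc(CN2CCC(NC(=O)c3ccc(N)nc3)CC2)ccc1C`: 8.27
Compound 3 `CCOc1cc(CN2CCC(NC(=O)c3cncc(C)c3)CC2)cc(OCC)c1F`: 7.7

Compound 1 sits at the low end of this small set. Compound 3 lies within the scatter of it, and compound 2 stands higher than compound 1 by a gap beyond the scatter.

The next compound to be tested is compound 4 `CCOc1cc(CN2CCC(NC(=O)c3ccc(N)nc3)CC2)cc(OCC)c1-c1ccc(F)cc1`. It departs from compound 1 at one place: methyl in place of phenyl on a saturated chain carbon bound to an oxygen on an aromatic ring. This is methyl in place of phenyl on a saturated chain carbon bound to an oxygen on an aromatic ring, or benzyloxy to ethoxy.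

Among the compounds with values here, no measured pair isolates this change, so the expectation is indirect. Compound 3 carries ethoxy and reads 7.7, although it differs from compound 1 in other ways too. Compound 2 reads 8.27, which keeps the upper side of the range open. In this assay, no shift beyond the scatter is expected. The estimated step is a number 0.09 log units higher from compound 1 to compound 4 (within the scatter). For compound 4 the expected value is 7.75, with an estimated range from 7.4 to 8.1.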

Compound 4, acid dissociation constant: 7.86
Estimate against measurement, compound 4: 0.11 log units below, within the range that was stated.
By their numbers in this assay, from the lowest: compounds 1, 3 and 4 (each within the scatter of the next); then compound 2.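

Within the data shown here, compound 1 and compound 4 form the first pair that isolates this position, and in this assay going from benzyloxy to ethoxy gives a number 0.20 log units higher from compound 1 to compound 4 (within the scatter) as the step. Phenyl, with its six heavy atoms and its aromatic ring, gives way to methyl, with a single carbon, and this read-out cannot tell the two compounds apart. No measurement at hand bears on the reason for this result.

From the compounds shown here alone, the pair covers only phenyl and methyl on a saturated chain carbon bound to an oxygen on an aromatic ring, so it remains open whether an amine, a carboxylic acid or a longer chain there would also stay within the scatter. Going by these compounds, it also remains open whether the same exchange would give a similar step on a core other than that of compound 1.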